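A few compounds are considered here, and "the series" means these few. Any claim that something is new, unique, unknown or untested is made for them only; others in the source may bear on it.

Within the data shown here, in a functional assay on K562 cells (Homo sapiens) for inhibition, read by trypan blue exclusion, with a stated time of 72 h (a higher number here means a weaker inhibitor, a lower number a stronger inhibitor), compound 1 `Cc1ccc(S(=O)(=O)c2cc3cnc(Nc4cnc5[nH]ccc5c4)nc3n(C)c2=O)cc1` gives 15000 nM and compound 2 `Cn1c(=O)c(S(=O)(=O)c2ccc(F)cc2F)cc2cnc(Nc3cnc4[nH]ccc4c3)nc21` gives 750 nM, the lower of the two numbers so far. Compound 3 `Cn1c(=O)c(S(=O)(=O)c2ccc(F)cc2)cc2cnc(Nc3cnc4[nH]ccc4c3)nc21` keeps the shared core and differs from compound 2 in one place: hydrogen in place of fluoro on an aromatic carbon. This is hydrogen in place of fluoro on an aromatic carbon, turning 2,4-difluorophenyl into 4-fluorophenyl. Among the measured compounds shown here, only one measured step bears on this: a 20-fold lower number from compound 1 to compound 2 (1.30 log units; beyond the scatter), which is large and beyond the scatter. That step replaces 4-methylphenyl with 2,4-difluorophenyl, so it changes two places on the aromatic ring and does not isolate the fluoro that leaves here. Part of that step is therefore expected to be given back, a moderate move to a higher number in this assay, though one close to the scatter remains possible. The expected change is a 2.9-fold higher number from compound 2 to compound 3 (0.47 log units; beyond the scatter). For compound 3 the estimated value is 2200 nM, with an expected range of 700 nM to 7000 nM.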

Compound 3, half-maximal inhibitory concentration: 750 nM
Compound 3: the middle estimate sits 2.9-fold (0.47 log units) above what was measured, and the stated range covers the measured number.
By their numbers in this assay, from the lowest: compounds 2 and 3 (each within the scatter of the next); then compound 1.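

In this assay, removing the fluoro from the aromatic carbon ortho to a large group gives no change at the digits printed from compound 2 to compound 3 (within the scatter), so this position shows no dependence on fluoro versus hydrogen within this pair. The large gain seen earlier now traces to a single exchange, fluoro in place of methyl on an aromatic carbon, with 4-methylphenyl going to 4-fluorophenyl and a 20-fold lower number from compound 1 to compound 3 (1.30 log units; beyond the scatter). No measurement here speaks to the cause of either result.

Open, from the compounds shown here alone, is whether the gain needs fluoro itself or follows from losing the methyl, a question that unsubstituted phenyl or 4-chlorophenyl would address. Also open, going by these compounds, is whether the aromatic carbon ortho to a large group accepts anything beyond hydrogen and fluoro, such as a methoxy group or an amine.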